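A few compounds are considered here, and "the series" means these few. Any claim that something is new, unique, unknown or untested is made for them only; others in the source may bear on it.

Measured in a functional assay on MGC-803 cells (Homo sapiens) for antiproliferative activity, read by MTT assay, with a stated time of 48 h; on this read-out higher numbers stand for an effect only at larger amounts of compound and lower numbers for an effect already at smaller amounts:

Compound 1 `CC1=NN(S(=O)(=O)c2ccc(F)cc2)C(c2cc(Br)ccc2O)C1` gives 15500 nM
Compound 2 `CC1=NN(S(=O)(=O)c2ccc(Cl)cc2)C(c2cc(Br)ccc2O)C1` gives > 60000 nM, a limit of the assay
Compound 3 `COc1ccc(S(=O)(=O)N2N=C(C)CC2c2cc(Br)ccc2O)cc1` gives 20300 nM

Compound 3 stands within the scatter of compound 1, with a 1.3-fold higher number from compound 1 to compound 3 (0.12 log units; within the scatter). Compound 2 reports only a limit, > 60000 nM, and an at least 2.9-fold lower number from compound 2 to compound 3 (0.47 log units; beyond the scatter) separates it from the methoxy compound.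

Compound 4 `CC1=NN(S(=O)(=O)c2ccc(C(F)(F)F)cc2)C(c2cc(Br)ccc2O)C1` carries trifluoromethyl in place of methoxy on an aromatic carbon, para to a large group (trifluoromethyl in place of methoxy on an aromatic carbon). Among the measured compounds shown here, no measured compound holds trifluoromethyl, so the evidence is indirect. Swapping fluoro for methoxy changed nothing beyond the scatter, whereas the chloro swap gave an at least 3.8-fold higher number from compound 1 to compound 2 (0.58 log units; beyond the scatter). These three compounds therefore show that a single swap here can either leave the number unchanged or raise it. A modest rise is the more cautious expectation, though no change beyond the scatter remains possible. The expected change is a 1.5-fold higher number from compound 3 to compound 4 (0.17 log units; within the scatter). The estimate for compound 4 is 30000 nM, with an expected range from 12000 nM to 60000 nM.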

Compound 4, half-maximal effective concentration: 30000 nM
Estimate against measurement, compound 4: no gap at the digits printed; the measured number falls inside the stated range.
By their numbers in this assay, from the lowest: compounds 1, 3 and 4 (each within the scatter of the next). At a limit, above all of these: compound 2.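

In this assay, trifluoromethyl on this aromatic carbon, para to a large group, stays within the scatter of both methoxy and fluoro, with a 1.5-fold higher number from compound 3 to compound 4 (0.17 log units; within the scatter) and a 1.9-fold higher number from compound 1 to compound 4 (0.29 log units; within the scatter). The hydrogen-bond acceptor of methoxy is therefore not required for a number in this range, since trifluoromethyl has none. Chloro remains the one swap that goes against this, yet its value is only a limit, and with an at least 2.0-fold lower number from compound 2 to compound 4 (0.30 log units; that floor lies within the scatter) trifluoromethyl is not clearly set apart from it: the limit of > 60000 nM in this assay, at which 1 of the 4 values shown sits.

The compounds shown leave open whether any group at this place gives a number lower than those of compounds 1, 3 and 4 by more than the scatter. They also do not tell how an amine or a carboxylic acid would behave here.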